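Reversed amide with a cyclohexylmethyl group: outlook for compound 4

A few compounds are considered here, and "the series" means these few. Any claim that something is new, unique, unknown or untested is made for them only; others in the source may bear on it.

Measured so far in an assay on CHO-K1 cells for displacement of a labelled ligand from prostaglandin E2 receptor EP1 subtype (Homo sapiens); a higher number here means a weaker inhibitor, a lower number a stronger inhibitor:
compound 1 `Cc1cc(C(=O)Nc2cccc(F)c2)nn1Cc1cc(Cl)ccc1OCc1ccccc1`, 200 nM
compound 2 `Cc1cc(C(=O)Nc2ccccn2)nn1Cc1cc(Cl)ccc1OCc1ccccc1`, 126 nM
compound 3 `Cc1cc(C(=O)NCc2ccncc2)nn1Cc1cc(Cl)ccc1OCc1ccccc1`, 79.4 nM

Compound 1 gives the highest of the three numbers. Its nearest neighbour is compound 2, a 1.6-fold lower number from compound 1 to compound 2 (0.20 log units; within the scatter); its furthest is compound 3, a 2.5-fold lower number from compound 1 to compound 3 (0.40 log units; beyond the scatter). Between the other two, a 1.6-fold lower number from compound 2 to compound 3 (0.20 log units; within the scatter).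

Compound 4 `Cc1cc(NC(=O)CC2CCCCC2)nn1Cc1cc(Cl)ccc1OCc1ccccc1` differs from compound 1 in one place: ((cyclohexylmethyl)carbonyl)amino in place of (3-fluorophenyl)carbamoyl on an aromatic carbon. Among the measured compounds shown here, none of the measured steps bears directly on this change; all three vary only the group on the amide-type nitrogen, and the amide stays in one orientation. Here the carbonyl and the nitrogen swap places and a non-aromatic ring enters. Direction is therefore open; a modest rise in the number is expected, a 2.0-fold higher number from compound 1 to compound 4 (0.30 log units; within the scatter). Compound 4 is estimated at 400 nM, within 100 nM to 1600 nM.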

Compound 4, half-maximal inhibitory concentration: 6.31 nM
Compound 4: the middle estimate sits 63-fold (1.80 log units) above what was measured; measured number below the stated range.
By their numbers in this assay, from the lowest: compound 4; then compounds 3, 2 and 1 (each within the scatter of the next, the first and the last beyond it).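

In this assay the position on the aromatic carbon proves far more responsive than the amide-type nitrogen alone suggested: ((cyclohexylmethyl)carbonyl)amino gives a 32-fold lower number from compound 1 to compound 4 (1.50 log units; beyond the scatter) and likewise a 20-fold lower number from compound 2 to compound 4 (1.30 log units; beyond the scatter) as well as a 13-fold lower number from compound 3 to compound 4 (1.10 log units; beyond the scatter) in this series. Compound 4 is thus the strongest of the four inhibitors shown, and the largest earlier step was only a 2.5-fold lower number from compound 1 to compound 3 (0.40 log units; beyond the scatter) among the amides. Nothing shown accounts for this gain.

Still open, on these data alone, is how much of the gain belongs to the swap of carbonyl and nitrogen and how much to the non-aromatic ring, since the two enter together. Also open, as far as these compounds go, is how a longer chain or a carboxylic acid in place of the cyclohexyl ring would read.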